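The source may hold more compounds than are shown below. What is called first, only, known or untested is meant among the compounds shown, and "the series" means these compounds.

Measured compounds:
Compound 1, `CC(C)(C)c1ccc(C(=O)/C=C/c2ccco2)cc1`, in an ADME assay on THP-1 cells (Homo sapiens) for cytotoxicity, read by resazurin assay, with a stated time of 72 h (on this read-out higher numbers stand for lower toxicity in this test and lower numbers for higher toxicity in this test), gives > 50000 nM, which is a limit of the assay and not a number.
Compound 2, `CCCCc1ccc(C(=O)/C=C/c2ccc([N+](=O)[O-])o2)cc1`, in this assay gives 48700 nM.

Compound 2 holds the only number shown. Compound 1 sits at the limit of > 50000 nM in this assay, at which 1 of the 2 values shown sits. Compound 3, `O=C(/C=C/c1ccc([N+](=O)[O-])o1)c1ccc(Br)cc1`, is still to be measured in this assay. The change is bromo in place of butyl on an aromatic carbon. No measured step of this kind exists among these compounds, so the data give no direction for it. The expected step is a 1.2-fold lower number from compound 2 to compound 3 (0.09 log units; within the scatter), none beyond the scatter. Compound 3 is estimated at 40000 nM, within a range from 20000 nM to 80000 nM.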

Compound 3, half-maximal cytotoxic concentration: 13400 nM
Compound 3: middle estimate off by 3.0-fold (0.47 log units), on the high side, and the stated range ends above it.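

In this assay, bromo in place of butyl on an aromatic carbon, para to a large group, gives a 3.6-fold lower number from compound 2 to compound 3 (0.56 log units; beyond the scatter). This shows that the group at this position can change the reading, with the bromo compound the more toxic of this pair. Compound 1 gives no second comparison, as its value is a limit and not a number: the limit of > 50000 nM in this assay, at which 1 of the 3 values shown sits.

A single step cannot separate the loss of the butyl chain from the arrival of bromine. As far as these compounds go, how a chloro group, an amine or a shorter chain would behave at this position remains open.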